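Benzyl to (3-methoxyphenyl)carbonyl on the shared core

The compounds below may be only part of what the source reports. "The series", "measured", "known", "first", "only" and "open" are said of these compounds alone.

Measured so far in a functional assay on HepG2 cells (Homo sapiens) for antiproliferative activity, read by MTT assay, with a stated time of 24 h (a higher number here means a weaker inhibitor, a lower number a stronger inhibitor), are two compounds
- compound 1 `C=CCOc1ccc2c(=O)c(-c3cc(OC)c(OC)cc3OC)coc2c1` gives 3450 nM
- compound 2 `COc1cc(OC)c(-c2coc3cc(OCc4ccccc4)ccc3c2=O)cc1OC` gives 1320 nM

Among the measured compounds shown here, compound 2 holds the lower of the two numbers, and the only measured step, a 2.6-fold lower number from compound 1 to compound 2 (0.42 log units; beyond the scatter), is modest but beyond the scatter. The next entry is compound 3 `COc1cccc(C(=O)Oc2ccc3c(=O)c(-c4cc(OC)c(OC)cc4OC)coc3c2)c1`, reached from compound 2 by one change: (3-methoxyphenyl)carbonyl in place of benzyl on an oxygen on an aromatic ring. In words, (3-methoxyphenyl)carbonyl stands in place of benzyl on an oxygen on an aromatic ring.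

The measured step bears on this only in part. For the measured compounds named here, it also alters the group carried on that oxygen, but no measured compound has a carbonyl there, so the data give no direct reading of this change. A step no larger than the modest one already seen is expected in this assay, with no firm direction and a slight lean towards a higher number. The expected change is a 1.4-fold higher number from compound 2 to compound 3 (0.13 log units; within the scatter) on this estimate. For compound 3 the expected value is 1800 nM with an estimated range from 600 nM to 5500 nM as the working figure.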

Compound 3, half-maximal inhibitory concentration: > 10000 nM
Compound 3: a limit, no number; the forecaster's own chance of this, stated with the estimate: 5%; middle value at least 5.5-fold (0.74 log units) away from the limit.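

Changing the group on this oxygen can move the reading in either direction in this assay: the earlier step from allyl to benzyl went towards a lower number, whereas benzyl to (3-methoxyphenyl)carbonyl gives an at least 7.5-fold higher number from compound 2 to compound 3 (0.87 log units; beyond the scatter). The same group also compares unfavourably with allyl, with an at least 2.8-fold higher number from compound 1 to compound 3 (0.46 log units; beyond the scatter), so among the three compounds on the shared core, the only one with a carbonyl on this oxygen has the highest reading, and tolerance at this position does not extend to every group with a six-membered aromatic ring. The reading for compound 3 is a limit and not a number, so neither step has a fixed size: the limit of > 10000 nM in this assay, at which 1 of the 3 values shown sits.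

This single change brings in the carbonyl and the methoxy group together, so the compounds shown cannot say which of them accounts for the shift; a 3-methoxybenzyl group or an unsubstituted benzoyl group on the same oxygen would separate the two. On these data alone, how this position responds to an entirely different kind of group, such as a longer chain ending in an amine or a carboxylic acid, also remains open.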